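Lengthening the Piperidine Linker of a Sigma-1 Ligand Series

The source may hold more compounds than are shown below. What is called first, only, known or untested is meant among the compounds shown, and "the series" means these compounds.

Compound 1 `CCCc1ccc2c(c1)sc(=O)n2CCN1CCCCC1` gives 0.6 nM in an assay on membranes from brain for displacement of a labelled ligand from Sigma non-opioid intracellular receptor 1 (Cavia porcellus); on this read-out lower numbers stand for stronger inhibition and higher numbers for weaker inhibition.
Compound 2 `CCC(=O)c1ccc2c(c1)sc(=O)n2CCCN1CCCCC1` gives 2.3 nM in this assay.
Compound 3 `CCCc1ccc2c(c1)sc(=O)n2CCCN1CCCCC1` gives 1.2 nM in this assay.

Compound 3 holds the second highest of the three numbers. The nearest of the other two is reached through a 1.9-fold lower number from compound 2 to compound 3 (0.28 log units; within the scatter), the furthest through a 2.0-fold higher number from compound 1 to compound 3 (0.30 log units; within the scatter), and both of these steps stay inside the usual scatter, so the three compounds cannot be ranked against each other.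

Compound 4 `CCCc1ccc2c(c1)sc(=O)n2CCCCN1CCCCC1` differs from compound 3 by (piperidin-1-yl)methyl in place of piperidin-1-yl on a saturated chain carbon, three bonds along the chain from an aromatic nitrogen. For the measured compounds named here, one measured step bears on this change: the same lengthening, made one bond nearer the aromatic nitrogen, gave a 2.0-fold higher number from compound 1 to compound 3 (0.30 log units; within the scatter). The step from compound 2 to compound 3 alters the group on the aromatic carbon instead and says nothing here. On that basis the next lengthening is expected to bring a step of a 1.5-fold higher number from compound 3 to compound 4 (0.18 log units; within the scatter) in this assay, leaning toward a higher number but not clearly beyond the scatter. Compound 4 is therefore estimated at 1.8 nM, with a likely range from 0.7 nM to 5 nM.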

Compound 4, inhibition constant: 2.9 nM
Estimate against measurement, compound 4: 1.6-fold (0.21 log units) below; the measured number falls inside the stated range.
By their numbers in this assay, from the lowest: compounds 1, 3, 2 and 4 (each within the scatter of the next, the first and the last beyond it).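

In this assay, for the compounds shown here, putting (piperidin-1-yl)methyl in place of piperidin-1-yl on a saturated chain carbon, three bonds along the chain from an aromatic nitrogen, brings a 2.4-fold higher number from compound 3 to compound 4 (0.38 log units; beyond the scatter) and is the first single lengthening to stand beyond the scatter. The same change made one bond nearer the aromatic nitrogen, a 2.0-fold higher number from compound 1 to compound 3 (0.30 log units; within the scatter) by contrast, stayed inside it, so chain length now has a readable effect on the number, though only a modest one at this position. Nothing shown gives a reason for this step.

The compounds shown leave open whether a longer chain than that of compound 4 would carry the number further in the same direction. They also leave open whether a morpholine ring in place of the piperidine, or propanoyl in place of propyl, would behave alike at this chain length.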